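The source may report more compounds than this note shows. Statements on the series, on what has been measured and on what is new or still open speak of the compounds shown alone.

Three related compounds have been measured in a functional assay on KARPAS-299 cells (Homo sapiens) for inhibition, read by CellTiter-Glo, with a stated time of 96 h (on this read-out higher numbers stand for weaker inhibition and lower numbers for stronger inhibition), so far. In that test, compound 1 (`CC(C)S(=O)(=O)c1nn(C)cc1Nc1nc(Nc2ccc(C3CCN(C)CC3)cc2OC2CC2)ncc1Cl`) gives 7 nM and compound 3 (`Cc1cc(Nc2ncc(Cl)c(Nc3cn(C)nc3S(=O)(=O)C(C)C)n2)c(OC(C)C)cc1C1CCNC1`) gives 28 nM, while compound 2 (`CC(C)S(=O)(=O)c1nn(C)cc1Nc1nc(Nc2cc(C#N)c(C3CCN(C)CC3)cc2OC2CC2)ncc1Cl`) gives 100 nM as the highest number of the three. Compound 2 is therefore the weakest inhibitor in this small set, and its gaps to both of the others lie beyond the scatter.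

The next compound is compound 4 (`CC(C)S(=O)(=O)c1nn(C)cc1Nc1nc(Nc2cc(Cl)c(C3CCN(C)CC3)cc2OC2CC2)ncc1Cl`), which differs from compound 2 at a single aromatic carbon, ortho to a 1-methylpiperidin-4-yl group and para to a cyclopropyloxy group (chloro in place of cyano on an aromatic carbon). Going by the values given here, only one measured step bears on this carbon: a 14-fold higher number from compound 1 to compound 2 (1.15 log units; beyond the scatter), a large change beyond the scatter, seen when cyano replaced hydrogen there. Among the compounds with values here, no measured compound carries chloro at this carbon, so that single step is a thin guide.

Still, taking cyano away may recover part of what it cost, so a lower number is expected in this assay, though probably not one that reaches the value of compound 1 at 7 nM. The expected change is a 3.3-fold lower number from compound 2 to compound 4 (0.52 log units; beyond the scatter), moderate in size and probably beyond the scatter. The estimate for compound 4 is 30 nM, with an expected range from 9 nM to 90 nM.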

Compound 4, half-maximal inhibitory concentration: 15 nM
Compound 4: middle estimate off by 2.0-fold (0.30 log units), on the high side; measured number inside the range.
By their numbers in this assay, from the lowest: compound 1; then compounds 4 and 3 (each within the scatter of the next); then compound 2.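

Compound 4 shows that this aromatic carbon, ortho to the 1-methylpiperidin-4-yl group and para to the cyclopropyloxy group, does not respond to every replacement of hydrogen in the same way: in this assay, the change from cyano to chloro gives a 6.7-fold lower number from compound 2 to compound 4 (0.82 log units; beyond the scatter), so most of the loss seen with cyano does not appear with chloro. Chloro is still not equal to hydrogen at this carbon, since the comparison with the unsubstituted compound gives a 2.1-fold higher number from compound 1 to compound 4 (0.33 log units; beyond the scatter), a modest step but one beyond the scatter; among these three compounds, hydrogen gives the lowest number, chloro an intermediate one and cyano the highest. Nothing available here explains why chloro and cyano differ at this carbon.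

The compounds shown leave open where fluoro, methyl or methoxy at this carbon would fall relative to hydrogen, chloro and cyano, and whether any group there could match or improve on hydrogen. They also leave open whether the same order would hold if an isopropoxy group replaced the cyclopropyloxy group or a different amine replaced the 1-methylpiperidin-4-yl group.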